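The compounds below may be only part of what the source reports. "The series", "measured", "known", "first", "only" and "open" are said of these compounds alone.

Measured compounds:
- compound 1, `CN1C=CN(C2OC(C(F)(F)F)=CN2c2ccc(S(N)(=O)=O)cc2)C=C1`: 55600 nM
- compound 2, `CC1=CN(c2ccc(S(N)(=O)=O)cc2)C(N2C=CN(C)C=C2)O1`: 98600 nM
- compound 3, `CN1C=CN(C2SC(C(F)(F)F)=CN2c2ccc(S(N)(=O)=O)cc2)C=C1`: 52400 nM

All three were tested in an ADME assay for inhibition of prostaglandin G/H synthase 1 (Rattus norvegicus), with a stated time of 30 min; a lower number here means a stronger inhibitor, a higher number a weaker inhibitor. Compound 1 and compound 2 share one core and differ in a single spot: methyl in place of trifluoromethyl on a double-bonded ring carbon. That change gave a 1.8-fold higher number from compound 1 to compound 2 (0.25 log units; within the scatter), so the two numbers do not separate from each other in a meaningful way. Compound 3 carries a different core, and the difference between the two cores is not broken down here; its value in this assay and that of compound 1 lie within the scatter of each other, as do those of compound 3 and compound 2.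

Compound 4, `CC1=CN(c2ccc(S(N)(=O)=O)cc2)C(N2C=CN(C)C=C2)S1`, has not been measured. It is made from compound 3 by methyl in place of trifluoromethyl on a double-bonded ring carbon. For the measured compounds named here, this is the same kind of change as the one from compound 1 to compound 2, but not the same: in compound 3 the five-membered non-aromatic ring holds one nitrogen and one sulfur and the group sits next to the ring sulfur, whereas in compound 1 the ring holds one nitrogen and one oxygen and the group sits next to the ring oxygen. Going by the values given here, the only guide to the size of the step is the earlier one, which stayed within the scatter, so compound 4 is expected to show a 1.7-fold higher number from compound 3 to compound 4 (0.23 log units; within the scatter) in this assay. Resting on the value of compound 3, 52400 nM, and on the step seen between compound 1 and compound 2, compound 4 is estimated at 90000 nM, with a likely range from 40000 nM to 220000 nM.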

Compound 4, half-maximal inhibitory concentration in the prostaglandin G/H synthase 1 assay: 76900 nM
Beside the measured number, compound 4's estimate is 1.2-fold (0.07 log units) above it; measured number inside the range.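

In the prostaglandin G/H synthase 1 assay, methyl in place of trifluoromethyl gave a 1.5-fold higher number from compound 3 to compound 4 (0.17 log units; within the scatter), and set beside the earlier step, the change behaves alike on the two cores: the same change on two cores in the prostaglandin G/H synthase 1 assay, a 1.8-fold higher number (0.25 log units; within the scatter) from compound 1 to compound 2 and a 1.5-fold higher number (0.17 log units; within the scatter) from compound 3 to compound 4, 1.2-fold (0.08 log units) apart, within the scatter of two such steps. For the compounds shown here, this shows that the small size of the step carries from the core of compound 1 to the core of compound 3, but since both steps lie within the scatter, it shows only that the change leaves this number without a clear shift on either core, not that it has a fixed effect that could be added to other compounds. In a physicochemical assay for lipophilicity (on this read-out lower numbers stand for lower lipophilicity and higher numbers for higher lipophilicity), compound 3 gives 2.38 and compound 4 gives 1.75, so the same change does give a clear shift, yet these values speak for this one pair alone, so they say nothing about whether that shift carries to the other core: the measured partition coefficient of compound 3, 2.38, and of compound 4, 1.75, a number 0.63 log units lower (beyond the scatter).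

The compounds shown leave open whether a different group on the double-bonded ring carbon, such as an ethyl chain, an amine or a carboxylic acid, would move the prostaglandin G/H synthase 1 assay number beyond the scatter. They also leave open whether the small step would hold on a core other than these two.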